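The source may report more compounds than this note shows. Statements on the series, on what has been measured and on what is new or still open speak of the compounds shown alone.

Compound 1 `Cc1cc(C2CCCCC2)c(S(C)(=O)=O)cc1C(=O)N=C(N)N` gives 22 nM in a functional assay for inhibition of sodium/hydrogen exchanger (Oryctolagus cuniculus); on this read-out lower numbers stand for stronger inhibition and higher numbers for weaker inhibition; compound 2 `Cc1cc(Sc2ccccc2)c(S(C)(=O)=O)cc1C(=O)N=C(N)N` gives 14 nM; compound 3 `Cc1cc(C(F)(F)F)c(S(C)(=O)=O)cc1C(=O)N=C(N)N` gives 37 nM.

Among these three, compound 3 carries the highest number. Its gap to compound 1 is within the scatter, whereas the step of a 2.6-fold higher number from compound 2 to compound 3 (0.42 log units; beyond the scatter) is beyond it. Compound 4 `Cc1cc(-n2ccc(=O)cc2)c(S(C)(=O)=O)cc1C(=O)N=C(N)N` differs from compound 3 by a group of 7 heavy atoms (5 carbon, 1 nitrogen, 1 oxygen; one six-membered aromatic ring with 1 hetero atom) in place of a group of 4 heavy atoms (1 carbon, 3 fluorine; no ring), on an aromatic carbon. Within the data shown here, two measured steps bear on this change, since both swap the trifluoromethyl at the same place for another group: a 1.7-fold higher number from compound 1 to compound 3 (0.23 log units; within the scatter) and a 2.6-fold higher number from compound 2 to compound 3 (0.42 log units; beyond the scatter). Read in the direction toward compound 4, replacing trifluoromethyl has given an equal or lower number, so a small step downward, or none beyond the scatter, is expected, a 1.7-fold lower number from compound 3 to compound 4 (0.23 log units; within the scatter). Compound 4 is therefore estimated at 22 nM, with a range from 8 nM to 60 nM.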

Compound 4, half-maximal inhibitory concentration: 75 nM
Compound 4: the middle estimate sits 3.4-fold (0.53 log units) below what was measured, and the stated range ends below it.
By their numbers in this assay, from the lowest: compounds 2, 1 and 3 (each within the scatter of the next, the first and the last beyond it); then compound 4.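

This position, ortho to a methylsulfonyl group, does not accept every replacement for trifluoromethyl equally: the six-membered aromatic ring with 1 hetero atom gives a 2.0-fold higher number from compound 3 to compound 4 (0.31 log units; beyond the scatter), the first replacement to raise the number. The same group also stands above the other two, with a 3.4-fold higher number from compound 1 to compound 4 (0.53 log units; beyond the scatter) and a 5.4-fold higher number from compound 2 to compound 4 (0.73 log units; beyond the scatter), so a group with as many heavy atoms as phenylsulfanyl does not by that alone keep the number low. Nothing measured here gives a reason for these shifts.

Going by these compounds, how an amine, a carboxylic acid or a longer alkyl chain would read at this position stays open. So does whether the shift follows the ring's nitrogen or its carbonyl oxygen.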